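Closing the Amine into a Phenyl-Bearing Pyrrolidine Ring

A few compounds are considered here, and "the series" means these few. Any claim that something is new, unique, unknown or untested is made for them only; others in the source may bear on it.

Three compounds share one core and differ only in the amine attached to a saturated chain carbon bound to an aromatic carbon. In an assay on cells for displacement of a labelled ligand from corticotropin-releasing factor receptor 1 (Homo sapiens), with a stated time of 100 min (on this read-out lower numbers stand for stronger inhibition and higher numbers for weaker inhibition), compound 1 `CCN(Cc1c(C(F)(F)F)nc2n(-c3c(C)cc(C)cc3C)c(Cl)cn12)CC1CC1` gives 9 nM, compound 2 `CCN(Cc1c(C(F)(F)F)nc2n(-c3c(C)cc(C)cc3C)c(Cl)cn12)CC1CCC1` gives 16 nM, and compound 3 `CCCN(Cc1ccccc1)Cc1c(C(F)(F)F)nc2n(-c3c(C)cc(C)cc3C)c(Cl)cn12` gives 170 nM. Compound 3 stands highest of the three, since a 19-fold higher number from compound 1 to compound 3 (1.28 log units; beyond the scatter) and an 11-fold higher number from compound 2 to compound 3 (1.03 log units; beyond the scatter), both beyond the scatter, whereas a 1.8-fold higher number from compound 1 to compound 2 (0.25 log units; within the scatter). Compound 4 `Cc1cc(C)c(-n2c(Cl)cn3c(CN4CCCC4c4ccccc4)c(C(F)(F)F)nc23)c(C)c1` alters compound 3 by 2-phenylpyrrolidin-1-yl in place of benzyl(propyl)amino on a saturated chain carbon bound to an aromatic carbon. Among the measured compounds shown here, no measured step covers a ring closure of this kind, so the two large steps only show that the benzyl(propyl)amino arrangement gave the weakest result seen. A moderate improvement is expected, so compound 4 is estimated at 90 nM, ranging from 20 nM to 400 nM, which would mean a 1.9-fold lower number from compound 3 to compound 4 (0.28 log units; within the scatter).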

Compound 4, inhibition constant: > 7000 nM
Compound 4 was reported as a limit (the forecaster's own chance of this, stated with the estimate: 5%); middle value at least 77-fold (1.89 log units) away from the limit.
By their numbers in this assay, from the lowest: compounds 1 and 2 (each within the scatter of the next); then compound 3. At a limit, above all of these: compound 4.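

In this assay compound 4 is reported only as a limit, not as a number: the limit of > 7000 nM in this assay, at which 1 of the 4 values shown sits. Although 2-phenylpyrrolidin-1-yl has the same heavy atoms as benzyl(propyl)amino, the swap gives an at least 41-fold higher number from compound 3 to compound 4 (1.61 log units; beyond the scatter), and the comparisons with the other two amines give an at least 430-fold higher number from compound 2 to compound 4 (2.64 log units; beyond the scatter) and an at least 770-fold higher number from compound 1 to compound 4 (2.89 log units; beyond the scatter). So at this saturated chain carbon, the arrangement of the amine's atoms matters, not just which atoms it contains, and this ring form is the poorest of the four.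

As far as these compounds go, whether the loss comes from the ring itself or from the phenyl on it remains open. An unsubstituted pyrrolidin-1-yl or a piperidin-1-yl at this place would help separate the two.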